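Amidine to imidazoline on the fused core: cytotoxicity notes

This account rests on a few compounds, and the source may have more. Where it says the series, first, only, none or still open, it means among the compounds named here.

Of the compounds shown here, two have been measured for cytotoxicity. Compound 1 `c1ccc(OCCCCCCOc2cccc(-c3cc4ccc(C5=NCCN5)cc4o3)c2)cc1` in an ADME assay on L6 cells (Rattus norvegicus) for cytotoxicity, read by resazurin assay, with a stated time of 70 h (on this read-out higher numbers stand for weaker inhibition and lower numbers for stronger inhibition), gives 1800 nM. Compound 2 `N=C(N)c1ccc2oc(-c3ccc(OCCCOc4ccccc4)cc3)cc2c1` in this assay gives 7300 nM, the highest of the two numbers; its gap to compound 1 lies beyond the scatter. Compound 3 `c1ccc(OCCCOc2ccc(-c3cc4cc(C5=NCCN5)ccc4o3)cc2)cc1` has not yet been measured in this assay. It differs from compound 2 in one place: a group of 5 heavy atoms (3 carbon, 2 nitrogen; one five-membered non-aromatic ring with 2 hetero atoms) in place of a group of 3 heavy atoms (1 carbon, 2 nitrogen; no ring), on an aromatic carbon The group that enters is the group compound 1 carries, and compound 1 gives 1800 nM in this assay; compound 3 keeps the chain of compound 2, so the two measured compounds do not isolate this change on its own. A moderate step toward a lower number is expected, a 1.8-fold lower number from compound 2 to compound 3 (0.26 log units; within the scatter). Compound 3 is estimated at 4000 nM in this assay, with a range from 1500 nM to 11000 nM.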

Compound 3, half-maximal inhibitory concentration: 10300 nM
Beside the measured number, compound 3's estimate is 2.6-fold (0.41 log units) below it, within the range that was stated.
By their numbers in this assay, from the lowest: compound 1; then compounds 2 and 3 (each within the scatter of the next).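

In this assay, placing the five-membered non-aromatic ring with 2 hetero atoms on this aromatic carbon of the shared core, where the open group of 3 heavy atoms stood, gives a 1.4-fold higher number from compound 2 to compound 3 (0.15 log units; within the scatter). Among these compounds, this pair offers the first reading of the change on its own, with the chain of compound 2 kept, and at this position the two groups cannot be told apart on this read-out. Nothing on hand offers an explanation for this outcome.

As far as these compounds go, whether the same exchange would read alike with the chain and ring attachment of compound 1 remains open. Also open, from the compounds shown here alone, is how a primary amine or a carboxylic acid on this aromatic carbon would read in this assay.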